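The source may hold more compounds than are shown below. What is called first, only, known or untested is meant among the compounds shown, and "the series" means these compounds.

Series notes, metabolic stability. Two compounds have a number in an ADME assay on microsomes from liver (Homo sapiens) for metabolic stability, tested at 2.5 uM (a lower number here means slower removal, a higher number faster removal of the compound), so far. Compound 1, `N#Cc1cccc(S(=O)(=O)c2cnc3cc(F)ccc3c2-c2cccc(Cl)c2)c1`, gives 0.99 mL/min in this assay. Compound 2, `O=S(=O)(c1ccc(F)c(Cl)c1)c1cnc2cc(F)ccc2c1-c1ccccc1F`, gives 1.07 mL/min in this assay. Compound 2 thus stands alongside compound 1: the gap between the two values lies within the usual scatter of repeated measurements, so the pair is read as one level rather than as two.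

The next compound is compound 3, `N#Cc1cccc(S(=O)(=O)c2cnc3cc(F)ccc3c2-c2ccccc2F)c1`, not yet measured in this assay. Set against compound 2, the change is 3-cyanophenyl in place of 3-chloro-4-fluorophenyl on a sulfonyl sulfur. Compound 3 carries the 3-cyanophenyl already present in compound 1 together with the remainder of compound 2, and both measured compounds sit at the same level. No step beyond the scatter is therefore expected in this assay; the step from compound 2 to compound 3 is estimated as a 1.1-fold lower number from compound 2 to compound 3 (0.03 log units; within the scatter). Compound 3 is expected to give about 1 mL/min in this assay, within a range of 0.5 mL/min to 2 mL/min.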

Compound 3, intrinsic clearance in a liver preparation (reported as CLH), per the amount of preparation that the assay uses: 1.39 mL/min
Estimate against measurement, compound 3: 1.4-fold (0.14 log units) below; the range from low to high includes it.
By their numbers in this assay, from the lowest: compounds 1, 2 and 3 (each within the scatter of the next).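

In this assay, the sulfonyl sulfur position now has a direct reading: 3-cyanophenyl in place of 3-chloro-4-fluorophenyl gives a 1.3-fold higher number from compound 2 to compound 3 (0.11 log units; within the scatter), so this exchange does not separate from the scatter. Within the data shown here, the aromatic carbon position gets its first reading as well: 2-fluorophenyl in place of 3-chlorophenyl gives a 1.4-fold higher number from compound 1 to compound 3 (0.15 log units; within the scatter), and here too no step can be separated from the scatter. No measurement shown bears on why either exchange leaves the read-out at one level.

Going by these compounds, all three compounds carry substituted phenyl groups at both positions, so it stays open whether an amine or a carboxylic acid in place of these groups on the sulfonyl sulfur would give a step beyond the scatter. The same question stands for a morpholine in place of the 2-fluorophenyl on the aromatic carbon.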